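Ring Swap on the Chain Carbon of a Weak Antagonist

The compounds below may be only part of what the source reports. "The series", "measured", "known", "first", "only" and "open" are said of these compounds alone.

Of the compounds shown here, three built on one shared core have been measured in an assay on CHO-K1 cells for antagonist activity at adenosine receptor A1 (Homo sapiens), read by a beta-galactosidase reporter, with stated times of 15 min and 6 h; a higher number here means a weaker inhibitor, a lower number a stronger inhibitor. Compound 1 `Nc1nc(-c2ccco2)nc2sc(CN3CC=CCC3)cc12` gives 150 nM, compound 2 `Nc1nc(-c2cocn2)nc2sc(CN3CC=CCC3)cc12` gives 2960 nM, and compound 3 `N#Cc1ccc(-c2nc(N)c3cc(CN4CCC(F)CC4)sc3n2)cc1` gives 8430 nM. Compound 3 thus stands highest of the three numbers, beyond the scatter from compound 2 and further still from compound 1. For the measured compounds named here, the one single-point step among them, a 20-fold higher number from compound 1 to compound 2 (1.30 log units; beyond the scatter), concerns the aromatic group on the core and is large.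

Compound 4 `N#Cc1ccc(-c2nc(N)c3cc(CN4CC=CCC4)sc3n2)cc1` differs from compound 3 elsewhere: a group of 6 heavy atoms (5 carbon, 1 nitrogen; one six-membered non-aromatic ring with 1 hetero atom) in place of a group of 7 heavy atoms (5 carbon, 1 nitrogen, 1 fluorine; one six-membered non-aromatic ring with 1 hetero atom), on a saturated chain carbon bound to an aromatic carbon. Going by the values given here, the entering group is the one carried by compound 1 and compound 2, yet neither of those has a partner differing from it only at that position, so no measured step bears directly on this change; the only step available alters a different part of the molecule. With nothing pointing either way, no step beyond the scatter is expected in this assay, a 1.3-fold lower number from compound 3 to compound 4 (0.11 log units; within the scatter). Compound 4 is therefore estimated at 6500 nM, with a range from 2200 nM to 19000 nM.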

Compound 4, inhibition constant: 1630 nM
Beside the measured number, compound 4's estimate is 4.0-fold (0.60 log units) above it, outside the stated range (below it).
By their numbers in this assay, from the lowest: compound 1; then compounds 4 and 2 (each within the scatter of the next); then compound 3.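

In this assay, for the compounds shown here, the group on the saturated chain carbon bound to an aromatic carbon now shows an effect of its own: a 5.2-fold lower number from compound 3 to compound 4 (0.71 log units; beyond the scatter) is a modest change beyond the scatter, the first reading at this position. With that group held constant, the aromatic group on the core can also be compared further: an 11-fold higher number from compound 1 to compound 4 (1.04 log units; beyond the scatter) is a large change, while a 1.8-fold lower number from compound 2 to compound 4 (0.26 log units; within the scatter) stays within the scatter. Furan-2-yl thus stands apart from both 4-cyanophenyl and 1,3-oxazol-4-yl, which these numbers do not separate.

On these data alone, whether the chain-carbon change carries the same size with furan-2-yl on the core remains open, since 4-fluoropiperidin-1-yl appears here only with 4-cyanophenyl. Also open is what an unsubstituted piperidine or a morpholine would give at this position, and no supporting data are available to explain any of these changes.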